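A few compounds are considered here, and "the series" means these few. Any claim that something is new, unique, unknown or untested is made for them only; others in the source may bear on it.

Of the compounds shown here, two sharing one core have been measured in an assay on CHO cells for displacement of a labelled ligand from histamine receptor H3 (Macaca mulatta); a higher number here means a weaker inhibitor, a lower number a stronger inhibitor. Compound 1 `Cc1cc(N2CCC(N3CCCC3C)C2)ccc1NC(=O)C1CC2CCC1C2` gives 19.9 nM in that assay. Compound 2 `Cc1cc(NC(=O)C2CCOCC2)ccc1N1CCC(N2CCCC2C)C1` gives 17 nM. Compound 2 carries the lower of the two numbers, yet its gap to compound 1 lies within the usual scatter of repeated measurements, so on these data the two compounds cannot be told apart.

Compound 3 `Cc1cc(NC(=O)C2CCCO2)ccc1N1CCC(N2CCCC2C)C1` has not yet been measured. It differs from compound 2 in a single place: oxolan-2-yl in place of oxan-4-yl on a carbonyl carbon. The group on the amide carbonyl thus becomes a smaller saturated ring joined at a different point, while the rest of the molecule is unchanged.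

For the measured compounds named here, no pair of measured compounds shows a change of this kind, so no measured step can guide the expectation. Such a swap of one small oxygen-containing ring for another on the amide carbonyl is expected to move the inhibition constant only a little, probably toward a somewhat higher number, and it may well stay inside the scatter. In this assay the expected step is a 1.8-fold higher number from compound 2 to compound 3 (0.25 log units; within the scatter). Compound 3 is accordingly estimated at 30 nM, within a range from 10 nM to 90 nM.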

Compound 3, inhibition constant: 17 nM
Compound 3: the middle estimate sits 1.8-fold (0.25 log units) above what was measured, within the range that was stated.
By their numbers in this assay, from the lowest: compounds 2, 3 and 1 (each within the scatter of the next).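

In this assay, for the compounds shown here, the swap of oxolan-2-yl in place of oxan-4-yl reads no change at the digits printed from compound 2 to compound 3 (within the scatter) and gives the first measured step at this position, on a carbonyl carbon whose other neighbour is an amide-type nitrogen. The two groups differ in ring size and in where the ring is joined, yet the measurement does not tell compound 2 and compound 3 apart, so here a six-membered ring with 1 hetero atom can give way to a five-membered one with no detectable penalty. Nothing measured here bears on why the two compounds read alike.

All three compounds shown carry a saturated ring on this carbonyl, so it remains open whether a group of another kind there, such as a straight butyl chain, a phenyl ring or a primary amine, would give a similar number. Also open, from the compounds shown here alone, is what each part of the swap contributes: cyclopentyl in place of oxolan-2-yl would replace the ring oxygen with carbon, while oxolan-3-yl would keep the ring and move only its point of attachment.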